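Ester to tertiary amide in one step

The source may report more compounds than this note shows. Statements on the series, on what has been measured and on what is new or still open speak of the compounds shown alone.

Compound 2 `CCOC(=O)Cc1sc(-c2ccccc2)nc1O` gives 950 nM in an assay on HEK293 cells for inhibition of transient receptor potential cation channel subfamily M member 8 (Homo sapiens), read by FLIPR, with stated times of 5 min and 3 min (on this read-out higher numbers stand for weaker inhibition and lower numbers for stronger inhibition), the only number shown so far. Compound 1 `CCNC(=O)c1sc(-c2ccccc2)nc1O` reaches only a limit, > 100000 nM, in this assay. For the measured compounds named here, the single measured step, an at least 100-fold lower number from compound 1 to compound 2 (2.02 log units; beyond the scatter), thus runs from a secondary amide to an ester. Compound 3 `CCN(C)C(=O)c1sc(-c2ccccc2)nc1O` turns back toward an amide: ethyl(methyl)carbamoyl in place of (ethoxycarbonyl)methyl on an aromatic carbon. The step from compound 1 to compound 2 bears on it and was large. A large step toward weaker inhibition is therefore expected, a 32-fold higher number from compound 2 to compound 3 (1.50 log units; beyond the scatter). Compound 3 is estimated at 30000 nM, within 3000 nM to 150000 nM, with a fair chance of a limit only.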

Compound 3, half-maximal inhibitory concentration: 6400 nM
For compound 3 the middle estimate is 4.7-fold (0.67 log units) above the measured one; low and high end bracket the measured number.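

Methyl in place of hydrogen on the amide-type nitrogen gives an at least 15-fold lower number from compound 1 to compound 3 (1.19 log units; beyond the scatter), so an amide on this aromatic carbon is compatible with measurable inhibition once that nitrogen carries no hydrogen. Ethyl(methyl)carbamoyl still trails (ethoxycarbonyl)methyl, with a 6.7-fold higher number from compound 2 to compound 3 (0.83 log units; beyond the scatter), which is a modest step where the secondary amide gave a large one. The value for compound 1 is a limit, so the gain from methyl has a lower bound only: the limit of > 100000 nM in this assay, at which 1 of the 3 values shown sits.

On these data alone, what a carboxylic acid in this place, or a propyl chain on the amide nitrogen, would give stays open.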